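Swapping isopropyl for butyl on a sulfur

A few compounds are considered here, and "the series" means these few. Any claim that something is new, unique, unknown or untested is made for them only; others in the source may bear on it.

Measured in an ADME assay on MT4 cells (Homo sapiens) for activation, read by MTT assay; a lower number here means that less compound is tolerated, a higher number that more compound is tolerated; each value is a limit:
- compound 1 `Cc1c(Cc2c(F)cccc2Cl)nc(SC(C)C)[nH]c1=O`: > 76000 nM
- compound 2 `Cc1c(C(C)c2c(F)cccc2Cl)nc(SC(C)C)[nH]c1=O`: > 15000 nM
- compound 3 `CCC(c1nc(SC(C)C)[nH]c(=O)c1C)c1c(F)cccc1Cl`: > 3000 nM

Compound 3 stands only at a limit of > 3000 nM, and no exact number is known for it. Compound 4 `CCCCSc1nc(C(CC)c2c(F)cccc2Cl)c(C)c(=O)[nH]1` differs from it in one place: butyl in place of isopropyl on a sulfur. Among the measured compounds shown here, none of the measured steps touches that group, and none has a readable size: a step that the two limits leave unreadable from compound 1 to compound 2, a step that the two limits leave unreadable from compound 1 to compound 3 and a step that the two limits leave unreadable from compound 2 to compound 3. The data therefore support no firm direction, and the step expected in this assay is a step that the limit leaves unreadable from compound 3 to compound 4. Compound 4 is estimated at 15000 nM, with an expected range of 3000 nM to 80000 nM.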

Compound 4, half-maximal cytotoxic concentration: > 3000 nM
Compound 4 ended at the assay's limit; the forecaster's own chance of this, stated with the estimate: 70%; the middle value is on the limit's open side.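

Compound 3 and compound 4 both stand only at a limit, so no step can be read between them. The compounds shown leave open whether butyl in place of isopropyl on a sulfur shifts the value in this assay at all.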